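Aminoalkyl replacement of benzyl on the shared core

The compounds below may be only part of what the source reports. "The series", "measured", "known", "first", "only" and "open" are said of these compounds alone.

Measured so far:
- compound 1, `O=C(NCc1ccc(F)cc1)c1nc(Br)c2cccnc2c1NCc1ccccc1`: > 20000 nM
- compound 2, `O=C(NCc1ccc(F)cc1)c1nc(NCCO)c2cccnc2c1O`: > 20000 nM
- compound 3, `CN(C)c1ccc(CNC(=O)c2nc(Br)c3cccnc3c2N[C@H]2CC[C@H](N)CC2)cc1`: 4000 nM

In a functional assay on MDA-MB-435 cells (Homo sapiens) for cytotoxicity, read by MTT assay, with a stated time of 72 h (a lower number here means a stronger inhibitor, a higher number a weaker inhibitor), compound 1 gives > 20000 nM, which is a limit of the assay and not a number. Compound 2 likewise reports only a limit, > 20000 nM. Within the data shown here, compound 3 is the one measured compound with a number, 4000 nM. Compound 1 therefore stands at the limit of > 20000 nM in this assay, at which 2 of the 3 values shown sit.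

Compound 4, `NCCCNc1c(C(=O)NCc2ccc(F)cc2)nc(Br)c2cccnc12`, is still unmeasured. Its change from compound 1 is 2-aminoethyl in place of phenyl on a saturated chain carbon bound to a nitrogen on an aromatic ring. Among the measured compounds shown here, compound 1 and compound 3 differ in more than one place, so their values show only that a compound of this core can give a number. A step toward stronger inhibition is expected for compound 4, but a limit remains quite possible; the estimated step is an at least 2.8-fold lower number from compound 1 to compound 4 (0.45 log units; beyond the scatter). Compound 4 is expected at 7000 nM, within 2000 nM to 20000 nM.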

Compound 4, half-maximal inhibitory concentration: 5000 nM
Estimate against measurement, compound 4: 1.4-fold (0.15 log units) above; low and high end bracket the measured number.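

Replacing benzyl with 3-aminopropyl on the shared core gives, in this assay, an at least 4.0-fold lower number from compound 1 to compound 4 (0.60 log units; beyond the scatter), the only step shown between compounds differing in one place. This position therefore responds to a change of this substituent alone, with the read-out of compound 4 being a number. The size of the step stays open-ended because compound 1 gives only a limit: the limit of > 20000 nM in this assay, at which 2 of the 4 values shown sit.

The compounds shown leave open whether the terminal amine or the loss of the phenyl ring carries the step. A plain propyl chain, a 3-hydroxypropyl chain or a longer aminoalkyl chain at this place would separate these readings.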